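The compounds below may be only part of what the source reports. "The series", "measured", "known", "first", "only" and "open" are said of these compounds alone.

Working notes on the series. Compound 1 `COc1ccccc1C1CCN(CC(=O)Nc2cccc(C)c2)CC1` and compound 2 `Cc1cccc(NC(=O)CN2CCC(c3ccc(O)cc3)CC2)c1` share one core and differ only in the aryl group on the saturated ring carbon. In a functional assay on HEK293 cells for agonist activity at D(4) dopamine receptor (Homo sapiens), read by FLIPR (on this read-out lower numbers stand for smaller maximal responses and higher numbers for larger maximal responses), compound 1 gives 43%, and in this assay compound 2 gives 60%; the step of a number 17 percentage points higher from compound 1 to compound 2 (beyond the scatter) is the only one measured so far, so compound 2 stands highest of the two numbers, beyond the scatter from compound 1.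

Compound 3 `Cc1cccc(NC(=O)CN2CCC(c3cccc(O)c3)CC2)c1` is unmeasured. It carries the change (3-hydroxyphenyl in place of 4-hydroxyphenyl on a saturated ring carbon), keeping the same atoms and the same hydroxyl group but at a different position on the aryl ring. Going by the values given here, no measured step swaps one hydroxyphenyl for another; the step from compound 1 to compound 2 bears on it only in that it also altered the aryl group on the same saturated ring carbon and moved the number by a modest amount. A step of similar size or smaller is therefore expected in this assay for compound 3, with the direction open. The expected step of a number 5 percentage points lower from compound 2 to compound 3 (within the scatter) is small. Compound 3 is estimated at 55%, within a range of 35% to 75%.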

Compound 3, largest response reached (reported as efficacy), in percent of the reference or control that the assay uses: 66%
Compound 3: the middle estimate sits 11 percentage points below what was measured; low and high end bracket the measured number.
By their numbers in this assay, from the lowest: compound 1; then compounds 2 and 3 (each within the scatter of the next).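

In this assay, the 3-hydroxyphenyl in place of the 4-hydroxyphenyl on the saturated ring carbon gives a number 6 percentage points higher from compound 2 to compound 3 (within the scatter), so this read-out does not separate the two hydroxyphenyl groups at this position. The separation from the 2-methoxyphenyl group now rests on two aryl groups rather than one: beside a number 17 percentage points higher from compound 1 to compound 2 (beyond the scatter) stands a number 23 percentage points higher from compound 1 to compound 3 (beyond the scatter), so both hydroxyphenyl compounds lie beyond the scatter from compound 1. No measurement on hand explains either the separation from compound 1 or the lack of one between compound 2 and compound 3.

Compound 1 differs from the two hydroxyphenyl compounds in both the group on the aryl ring and its place on that ring, so the compounds shown cannot say which of the two accounts for the step, and a 3-methoxyphenyl or an unsubstituted phenyl at the same saturated ring carbon would bear on this. From the compounds shown here alone, it also remains open whether the hydroxyl group can give way to another group on the aryl ring, such as an amine or a carboxylic acid, and how the response at this receptor would then compare.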